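This account rests on a few compounds, and the source may have more. Where it says the series, first, only, none or still open, it means among the compounds named here.

Measured compounds in a functional assay on HeLa S3 cells (Homo sapiens) for antiproliferative activity, read by XTT assay, with a stated time of 72 h; on this read-out higher numbers stand for weaker inhibition and lower numbers for stronger inhibition:
- compound 1 `C#Cc1cn([C@@H]2O[C@H](CO)[C@@H](O)[C@H]2O)c2ncnc(C)c12`: 14700 nM
- compound 2 `C#Cc1cn([C@@H]2O[C@H](CO)[C@@H](O)[C@H]2O)c2ncnc(N(C)C)c12`: 810 nM
- compound 3 `C#Cc1cn([C@@H]2O[C@H](CO)[C@@H](O)[C@H]2O)c2nc(N)nc(OC)c12`: > 20000 nM

Compound 3 stands at the top of the shown numbers: its entry in this assay is a limit of the assay, not a number, namely (the limit of > 20000 nM in this assay, at which 1 of the 3 values shown sits). Within the data shown here, compound 1 gives 14700 nM in this assay and compound 2 gives 810 nM; the one measured step, an 18-fold lower number from compound 1 to compound 2 (1.26 log units; beyond the scatter), concerns dimethylamino in place of methyl on an aromatic carbon and is the only step beyond the scatter in this set.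

Compound 4 `C#Cc1cn([C@@H]2O[C@H](CO)[C@@H](O)[C@H]2O)c2ncnc(OC)c12` is not yet measured. It differs from compound 3 as follows: hydrogen in place of amino on an aromatic carbon. Among the measured compounds shown here, no measured step touches an amino group, so the step from compound 1 to compound 2 does not bear directly on this change; it only shows that substitution on the shared core can move this assay by a large amount. With compound 3 at a limit, the direction of the step cannot be fixed from the data. Compound 4 is expected to remain weak, with an estimated 16000 nM (range 4000 nM to 40000 nM), which would mean an estimated at least 1.2-fold lower number from compound 3 to compound 4 (0.09 log units; that floor lies within the scatter).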

Compound 4, half-maximal inhibitory concentration: 1730 nM
The estimate for compound 4 lay 9.2-fold (0.97 log units) above the measured number; the measured number lies below the stated range.
By their numbers in this assay, from the lowest: compound 2; then compound 4; then compound 1. At a limit, above all of these: compound 3.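

In this assay compound 3 is held at a limit, not a number: the limit of > 20000 nM in this assay, at which 1 of the 4 values shown sits.

With hydrogen in place of amino between two ring nitrogen atoms, the methoxy compounds show an at least 11-fold lower number from compound 3 to compound 4 (1.06 log units; beyond the scatter), so this position can matter strongly in this pair. With hydrogen there, methoxy in place of methyl gives an 8.5-fold lower number from compound 1 to compound 4 (0.93 log units; beyond the scatter), while methoxy in place of dimethylamino gives a 2.1-fold higher number from compound 2 to compound 4 (0.33 log units; beyond the scatter), placing methoxy between the other two groups in these three compounds only.

Among these compounds, whether amino has a similar effect alongside methyl or dimethylamino remains open, as the only pair for this change carries methoxy. Also open, from the compounds shown here alone, is how a chlorine atom, an ethoxy group or a cyclic amine such as pyrrolidine would rank on that aromatic carbon.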